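A few compounds are considered here, and "the series" means these few. Any claim that something is new, unique, unknown or untested is made for them only; others in the source may bear on it.

The compounds measured so far:
- compound 1 `CCCc1nc(-c2ccccc2)c(CNCCN2CCN(c3cccc(C)c3C)CC2)o1`: 66.7%
- compound 2 `CCCc1nc(-c2ccccc2)c(CNCCN2CCN(c3cccc(OC)c3)CC2)o1`: 40.2%
- compound 3 `CCCc1nc(-c2ccccc2)c(CNCCN2CCN(c3ccccc3)CC2)o1`: 54.3%

In an assay on HEK293 cells for inhibition of Voltage-dependent T-type calcium channel subunit alpha-1G (Homo sapiens), read by fluorescence, tested at 10 uM (on this read-out lower numbers stand for less inhibition and higher numbers for more inhibition at the one concentration tested (going by the name of the read-out)), compound 3 stands second highest of the three numbers; its distances to the others are a number 12.4 percentage points lower from compound 1 to compound 3 (beyond the scatter) and a number 14.1 percentage points higher from compound 2 to compound 3 (beyond the scatter). Compound 4 `CCCc1nc(-c2ccccc2)c(CNCCN2CCN(c3ccc(OC)cc3)CC2)o1` differs from compound 3 by methoxy in place of hydrogen on an aromatic carbon. Within the data shown here, the one measured step that bears on this is a number 14.1 percentage points higher from compound 2 to compound 3 (beyond the scatter), where removing a methoxy raised the number; read in reverse, adding a methoxy would be expected to lower it by a modest amount, though that methoxy sat at a different place and no step for this exact position exists. Compound 4 is therefore expected to give about 44%, in a range from 26% to 62%, which means an estimated step of a number 10.3 percentage points lower from compound 3 to compound 4 (beyond the scatter).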

Compound 4, a percentage reported as inhibition, at one concentration (the size of the read-out at that concentration, not a potency): 51.5%
Beside the measured number, compound 4's estimate is 7.5 percentage points below it; the range from low to high includes it.
By their numbers in this assay, from the lowest: compound 2; then compounds 4 and 3 (each within the scatter of the next); then compound 1.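

In this assay, methoxy on the aromatic carbon para to a large group gives a number 2.8 percentage points lower from compound 3 to compound 4 (within the scatter), so at this place the group leaves the read-out indistinguishable from plain phenyl. Where the methoxy sits does count, as the change from 3-methoxyphenyl to 4-methoxyphenyl gives a number 11.3 percentage points higher from compound 2 to compound 4 (beyond the scatter), while 4-methoxyphenyl in place of 2,3-dimethylphenyl gives a number 15.2 percentage points lower from compound 1 to compound 4 (beyond the scatter). Nothing available explains these differences. From the compounds shown here alone, whether a hydroxyl, a chlorine or an ethoxy at this same place would also match phenyl remains open, as does whether a methyl there alone would approach the 2,3-dimethylphenyl compound.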